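This account rests on a few compounds, and the source may have more. Where it says the series, first, only, none or still open, it means among the compounds named here.

Measured so far in a functional assay on MIA PaCa-2 cells (Homo sapiens) for cytotoxicity, read by MTT assay, with a stated time of 72 h; on this read-out lower numbers stand for stronger inhibition and higher numbers for weaker inhibition:
- compound 1 `CN1CCN(c2ccc(NC3=CC(=O)c4ncncc4C3=O)cc2)CC1` gives 530 nM (lower of the two)
- compound 2 `CCc1ccc(-c2ccc(NC3=CC(=O)c4ncncc4C3=O)cc2)cc1` gives 1500 nM (higher of the two)

Among the compounds with values here, compound 2 holds the higher of the two numbers, and compound 1 is its only measured neighbour. The next compound to read is compound 3 `O=C1C(Nc2ccc(N3CCCCC3)cc2)=CC(=O)c2ncncc21` in which piperidin-1-yl takes the place of 4-ethylphenyl, piperidin-1-yl in place of 4-ethylphenyl on an aromatic carbon on an aromatic carbon of a six-membered aromatic ring of carbon only, para to a large group.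

Within the data shown here, one measured step bears on this change: a 2.8-fold higher number from compound 1 to compound 2 (0.45 log units; beyond the scatter) when 4-ethylphenyl replaced 4-methylpiperazin-1-yl on an aromatic carbon. That step is modest. Among the measured compounds shown here, compound 3, like compound 1, carries a six-membered non-aromatic ring there, so a step of similar size in the opposite direction is expected in this assay although a single pair fixes no pattern and no piperidin-1-yl compound has yet been measured. The expected change is a 2.3-fold lower number from compound 2 to compound 3 (0.36 log units; beyond the scatter) as an estimate. Compound 3 is estimated at 650 nM (expected range 220 nM to 1800 nM).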

Compound 3, half-maximal inhibitory concentration: 2400 nM
The estimate for compound 3 lay 3.7-fold (0.57 log units) below the measured number; measured number outside the range, above it.
By their numbers in this assay, from the lowest: compound 1; then compounds 2 and 3 (each within the scatter of the next).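

Carrying a six-membered non-aromatic ring on this aromatic carbon does not by itself keep the number low in this assay: replacing 4-methylpiperazin-1-yl with piperidin-1-yl gives a 4.5-fold higher number from compound 1 to compound 3 (0.66 log units; beyond the scatter), a step beyond the scatter. Replacing 4-ethylphenyl with piperidin-1-yl gives a 1.6-fold higher number from compound 2 to compound 3 (0.20 log units; within the scatter), so this change, from an aromatic ring to a non-aromatic ring with one hetero atom, does not separate the two compounds, and compound 1 alone stands apart, with steps to both others beyond the scatter. No available evidence accounts for this difference between the 4-methylpiperazin-1-yl group and the other two groups.

The compounds shown leave open whether the lower number of compound 1 goes with the whole 4-methylpiperazin-1-yl group or only with part of it, a question that piperazin-1-yl without the methyl, morpholin-4-yl or 4-methylpiperidin-1-yl at the same place could address. They also leave open whether a ring is needed there at all, which an open-chain amine such as dimethylamino could test.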